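The source may hold more compounds than are shown below. What is called first, only, known or untested is meant among the compounds shown, and "the series" means these compounds.

Measured compounds in this assay:

- compound 1, `CCCCCCCCn1cc(/C=C/C(=O)c2ccc(NC(=O)CN3CCN(c4ccccc4)CC3)cc2)nn1`: 31900 nM
- compound 2, `CCCCCCCCn1cc(/C=C/C(=O)c2ccc(NC(=O)CN3CCN(c4ccccc4F)CC3)cc2)nn1`: 68600 nM
- compound 3, `CCCCCCCCn1cc(/C=C/C(=O)c2ccc(NC(=O)CN3CCN(c4ccccc4OC)CC3)cc2)nn1`: 30000 nM

All three share one core and differ only in the substituent on an aromatic carbon of the outer ring. In a functional assay on MCF7 cells (Homo sapiens) for inhibition, read by MTT assay (a lower number here means a stronger inhibitor, a higher number a weaker inhibitor), compound 3 gives 30000 nM, the lowest of the three numbers, but its nearest neighbour is compound 1 and a 1.1-fold lower number from compound 1 to compound 3 (0.03 log units; within the scatter), so the two are not separated. The fluoro analogue stands apart: a 2.2-fold higher number from compound 1 to compound 2 (0.33 log units; beyond the scatter), and a 2.3-fold lower number from compound 2 to compound 3 (0.36 log units; beyond the scatter). Neither of those steps is large.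

Compound 4, `CCCCCCCCCCn1cc(/C=C/C(=O)c2ccc(NC(=O)CN3CCN(c4ccccc4OC)CC3)cc2)nn1`, differs from compound 3 by ethyl in place of hydrogen on a saturated chain carbon, eight bonds along the chain from an aromatic nitrogen. Going by the values given here, no measured step bears on this change: every step in hand concerns the substituent on the aromatic carbon, and the saturated chain is the same in all three measured compounds. There is therefore no basis in these numbers for a shift in either direction, and the expectation is a step of the same order as the smaller aromatic substitutions or none beyond the scatter. The number for compound 4 is expected to sit close to that of compound 3, with a 1.2-fold lower number from compound 3 to compound 4 (0.08 log units; within the scatter) as the estimated step. Compound 4 is estimated at 25000 nM, within a range of 9000 nM to 70000 nM.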

Compound 4, half-maximal inhibitory concentration: 44800 nM
Compound 4: the middle estimate sits 1.8-fold (0.25 log units) below what was measured; low and high end bracket the measured number.
By their numbers in this assay, from the lowest: compounds 3, 1, 4 and 2 (each within the scatter of the next, the first and the last beyond it).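

Going by these compounds alone, the saturated chain can now be read for the first time, as all the earlier steps concerned only the substituent on the aromatic carbon. In this assay, ethyl in place of hydrogen on a saturated chain carbon, eight bonds along the chain from an aromatic nitrogen, gives a 1.5-fold higher number from compound 3 to compound 4 (0.17 log units; within the scatter) and so does not separate the two compounds, which means this added ethyl leaves the number unresolved from that of the parent within the methoxy pair. No supporting data accompany this result, so the step stands as an observation without any explanation.

From the compounds shown here alone, this reading rests on a single pair, so it remains open whether the same ethyl change would behave alike on the unsubstituted or fluoro compounds. Also open, going by these compounds, is whether a longer chain, or a chain carrying an amine or a carboxylic acid at this position, would move the number beyond the scatter in either direction.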